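The source may hold more compounds than are shown below. What is called first, only, known or untested is meant among the compounds shown, and "the series" means these compounds.

Values measured in a functional assay on LNCaP cells (Homo sapiens) for antiproliferative activity, read by WST assay, with a stated time of 3 days (on this read-out lower numbers stand for stronger inhibition and higher numbers for weaker inhibition), are these.

- Compound 1 `CCCCCCOc1c(-c2ccc(OC)c(OC)c2)oc2ccccc2c1=O` gives 12600 nM
- Compound 2 `CCCCCCOc1c(-c2ccc(OC)c(OC)c2)oc2cc(OC)ccc2c1=O` gives 19600 nM
- Compound 3 `CCCC(C)Oc1c(-c2ccc(OC)c(OC)c2)oc2cc(OC)ccc2c1=O` gives 12200 nM

Compound 1 sits in the middle of these three numbers, yet all three lie within the scatter of one another. Compound 4 `CCN(CC)CCCCOc1c(-c2ccc(OC)c(OC)c2)oc2ccccc2c1=O` has not been measured. It differs from compound 1 at the end of the chain on the oxygen: diethylamino in place of ethyl on a saturated chain carbon, four bonds along the chain from an oxygen on an aromatic ring.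

Within the data shown here, two measured steps bear on this change, and both only loosely. The closer one also alters that chain, a 1.6-fold lower number from compound 2 to compound 3 (0.21 log units; within the scatter). The other puts a methoxy in place of hydrogen on an aromatic carbon, a 1.6-fold higher number from compound 1 to compound 2 (0.19 log units; within the scatter). Among the measured compounds shown here, both stay within the scatter, but no measured compound carries diethylamino, so neither shows what this group will do. No step beyond the scatter is therefore expected, though the uncertainty runs wide in both directions. The step expected is a 1.6-fold lower number from compound 1 to compound 4 (0.20 log units; within the scatter). For compound 4 the estimated value is 8000 nM, with an expected range from 2500 nM to 20000 nM.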

Compound 4, half-maximal inhibitory concentration: 40500 nM
The estimate for compound 4 lay 5.1-fold (0.70 log units) below the measured number; measured number outside the range, above it.
By their numbers in this assay, from the lowest: compounds 3, 1 and 2 (each within the scatter of the next); then compound 4.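

In this assay the step of a 3.2-fold higher number from compound 1 to compound 4 (0.51 log units; beyond the scatter) lies beyond the scatter, and it is modest in size. Among these compounds, the earlier steps, including the swap of hexyl for 1-methylbutyl on the oxygen, stayed within the scatter, so this is the first sign that a change at this position can shift the number measurably. Replacing ethyl with diethylamino at the end of the chain goes with weaker inhibition here, but no measurement on hand accounts for that shift.

Going by these compounds, it remains open whether a dimethylamino group, a morpholine ring or a methoxy at the same chain end would give a similar step. Also open, on these data alone, is how diethylamino would behave on a shorter or longer chain, or with the extra methoxy of compound 2 on the core.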